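The compounds below may be only part of what the source reports. "The series", "measured", "known", "first", "only" and "open" are said of these compounds alone.

Within the data shown here, in an ADME assay on MDBK cells (Bos taurus) for cytotoxicity (on this read-out lower numbers stand for higher toxicity in this test and higher numbers for lower toxicity in this test), compound 2 `Brc1ccc(Cn2ccc3nc(-c4ccccc4)nc-3c2)cc1` gives 83000 nM, the only plain number recorded for this series. Compound 1 `COc1ccc(Cn2ccc3nc(-c4ccccc4)nc-3c2)cc1` yields in this assay only a limit of the assay, > 100000 nM. Among the measured compounds shown here, the sole measured step, an at least 1.2-fold lower number from compound 1 to compound 2 (0.08 log units; that floor lies within the scatter), therefore rests on that limit of > 100000 nM in this assay, at which 1 of the 2 values shown sits, and carries little weight. Compound 3 `c1ccc(-c2nc3ccn(Cc4cccnc4)cc-3n2)cc1` differs from compound 2 in one place: pyridin-3-yl in place of 4-bromophenyl on a saturated chain carbon bound to an aromatic nitrogen. For the measured compounds named here, no measured step covers such an exchange, so the account expects for compound 3 a step of a 1.2-fold higher number from compound 2 to compound 3 (0.08 log units; within the scatter), nothing beyond the scatter. The estimate for compound 3 is 100000 nM, with a range from 40000 nM to 300000 nM.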

Compound 3, half-maximal cytotoxic concentration: > 100000 nM
Compound 3 was reported as a limit; the forecaster's own chance of this, stated with the estimate: 50%; the middle value lies on the limit itself.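

In this assay, pyridin-3-yl in place of 4-bromophenyl on a saturated chain carbon bound to an aromatic nitrogen gives an at least 1.2-fold higher number from compound 2 to compound 3 (0.08 log units; that floor lies within the scatter). Among these compounds, this is the first exchange at this place to bring in a ring with a hetero atom, and it shows no drop in the number. The step between compound 1 and compound 3 cannot be read, and the series now sits largely at one ceiling: the limit of > 100000 nM in this assay, at which 2 of the 3 values shown sit.

As far as these compounds go, whether any group at this place can lower the number beyond the scatter stays open. All three compounds carry a six-membered aromatic ring there, so a carboxylic acid, an aliphatic amine or a longer chain remains untested in what is shown.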